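This account rests on a few compounds, and the source may have more. Where it says the series, first, only, none or still open, it means among the compounds named here.

Measured compounds:
compound 1 `O=C(CCCCC1CCSS1)NCc1cn(CCCCCOc2ccc3ccc(=O)oc3c2)nn1`, 71.3%
compound 2 `O=C(CCCCC1CCSS1)NCc1cn(CCCCCOc2ccc3cc(-c4ccccc4)c(=O)oc3c2)nn1`, 26.3%
compound 3 `COc1ccc(-c2cc3ccc(OCCCCCn4cc(CNC(=O)CCCCC5CCSS5)nn4)cc3oc2=O)cc1`, 45.5%

All three were run in a functional assay on PC-12 cells (Rattus norvegicus) for cytotoxicity, read by MTT assay, with stated times of 3 h and 2 h, tested at 10 uM; on this read-out lower numbers stand for a weaker effect and higher numbers for a stronger effect at the one concentration tested. Within this set compound 3 stands second highest of the three: compound 2 sits nearest to it, a number 19.2 percentage points higher from compound 2 to compound 3 (beyond the scatter), and compound 1 sits furthest, a number 25.8 percentage points lower from compound 1 to compound 3 (beyond the scatter). The largest single step in the series is a number 45 percentage points lower from compound 1 to compound 2 (beyond the scatter).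

The next compound, compound 4 `COc1ccc(-c2cc3ccc(OCCCCCn4cc(CNC(=O)CCCCC5CCSS5)nn4)cc3oc2=O)cc1OC`, has not yet been measured. It differs from compound 3 as follows: methoxy in place of hydrogen on an aromatic carbon. Cut one bond further out, the same difference reads 4-methoxyphenyl to 3,4-dimethoxyphenyl.

Among the measured compounds shown here, only one measured step is of the same kind, namely methoxy in place of hydrogen on an aromatic carbon: a number 19.2 percentage points higher from compound 2 to compound 3 (beyond the scatter), a modest rise beyond the scatter. For the measured compounds named here, no second example of this change exists, so the direction rests on a single pair and the size is uncertain. A modest rise is nevertheless the more likely outcome because of a number 19.2 percentage points higher from compound 2 to compound 3 (beyond the scatter).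

The step from compound 3 to compound 4 is expected to be a number 9.5 percentage points higher from compound 3 to compound 4 (within the scatter). Compound 4 is therefore estimated at 55%, with a range from 35% to 75%.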

Compound 4, a percentage reported as activity, at one concentration (the size of the read-out at that concentration, not a potency): 50.5%
Beside the measured number, compound 4's estimate is 4.5 percentage points above it; low and high end bracket the measured number.
By their numbers in this assay, from the lowest: compound 2; then compounds 3 and 4 (each within the scatter of the next); then compound 1.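

In this assay, methoxy at the position ortho to a methoxy group gives a number 5 percentage points higher from compound 3 to compound 4 (within the scatter), so the step beyond the scatter seen with the first methoxy, a number 19.2 percentage points higher from compound 2 to compound 3 (beyond the scatter), does not repeat at this position. The 3,4-dimethoxyphenyl group stays clear of both reference points, with a number 24.2 percentage points higher from compound 2 to compound 4 (beyond the scatter) and a number 20.8 percentage points lower from compound 1 to compound 4 (beyond the scatter), so a second methoxy leaves the series' placing of the substituted aryl compounds as it was with one. Nothing at hand explains these steps.

Open, as far as these compounds go, is whether the result is particular to methoxy at this position, or whether an amine, a carboxylic acid or a longer chain such as butoxy there would move the number beyond the scatter. From the compounds shown here alone, how these compounds compare at other concentrations also remains open.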